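The source may hold more compounds than are shown below. What is called first, only, known or untested is meant among the compounds shown, and "the series" means these compounds.

Of the compounds shown here, two have been tested in a toxicity assay on THP-1 cells (Homo sapiens) for inhibition; on this read-out higher numbers stand for lower toxicity in this test and lower numbers for higher toxicity in this test. For compound 1 `CCCn1c(-c2ccc(OC)cc2)cnc1NC(=O)c1ccc(F)cc1` the result is a limit of the test rather than a number: compound 1 gives > 100000 nM. For compound 2 `COc1ccc(-c2cnc(NC(=O)c3ccccc3C#N)n2C)cc1` the result is likewise a limit, and compound 2 gives > 100000 nM. Within the data shown here, compound 2 therefore stands at the ceiling of the test, together with the only other value available, which is summed up as the limit of > 100000 nM in this assay, at which 2 of the 2 values shown sit. Among the measured compounds shown here, no step between two measured compounds exists here, so the measured pairs say nothing about how large an effect a structural change can have in this test.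

Compound 3 `COc1ccc(-c2cnc(NC(=O)c3ccc(Cl)cc3)n2C)cc1` has not yet been measured. It differs from compound 2 in one place (4-chlorophenyl in place of 2-cyanophenyl on a carbonyl carbon). Because both measured values sit at the limit of > 100000 nM in this assay, at which 2 of the 2 values shown sit, the step is expected to be a number no higher from compound 2 to compound 3 (the limit leaves the size open), that is, no shift beyond the usual scatter. Compound 3 is accordingly expected to give 100000 nM, with a likely range from 40000 nM to 300000 nM. The most probable outcome for compound 3 is that the test again reports only a limit.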

Compound 3, half-maximal cytotoxic concentration: > 100000 nM
Compound 3 ended at the assay's limit; the forecaster's own chance of this, stated with the estimate: 75%; the middle value lies on the limit itself.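

Compound 2 and compound 3 both give a limit of the test rather than a number in this assay, so the size of the step between them cannot be read. The compounds shown leave open at what concentration each would become toxic to these cells, and whether any structural change would alter that concentration.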